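Bromo in Place of Trifluoromethyl on the Triazole Side Arm

A few compounds are considered here, and "the series" means these few. Any claim that something is new, unique, unknown or untested is made for them only; others in the source may bear on it.

Compounds measured so far in a functional assay on SMMC-7721 cells (Homo sapiens) for cytotoxicity, read by MTT assay, with a stated time of 4 days; on this read-out higher numbers stand for weaker inhibition and lower numbers for stronger inhibition:
- Compound 1, `COc1ccc(-c2cn(C[C@H]3c4c(ccc(O)c4C)[C@@H]4CC[C@@]5(C)C[C@]43CC5=O)nn2)cc1`, gives only a limit of the assay, > 20000 nM.
- Compound 2, `Cc1ccc(S(=O)(=O)Oc2ccc3c(c2C)[C@H](Cn2cc(-c4ccc(C(F)(F)F)cc4)nn2)[C@@]24CC(=O)[C@@](C)(CC[C@@H]32)C4)cc1`, gives only a limit of the assay, > 20000 nM.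

Neither result is a number. Compound 2 stands at the edge of what this assay can report, and it shares that position with compound 1, since both values sit at the limit of > 20000 nM in this assay, at which 2 of the 2 values shown sit. No step between two measured numbers is therefore available, and nothing shown ranks one compound over the other.

Compound 3, `Cc1ccc(S(=O)(=O)Oc2ccc3c(c2C)[C@H](Cn2cc(-c4ccc(Br)cc4)nn2)[C@@]24CC(=O)[C@@](C)(CC[C@@H]32)C4)cc1`, is the next compound to be measured in this assay. It differs from compound 2 in one place: bromo in place of trifluoromethyl on an aromatic carbon. The core, the sulfonate ester and the triazole-bearing side arm are kept; only the group at the far end of the pendant aromatic ring changes.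

With compound 2 already at the limit, the step from compound 2 to compound 3 is expected to be a step that the limit leaves unreadable from compound 2 to compound 3, that is, no movement beyond the scatter is anticipated. Compound 3 is accordingly estimated to show 25000 nM, within a range from 10000 nM to 60000 nM, and most likely the assay will again report only a limit.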

Compound 3, half-maximal inhibitory concentration: > 20000 nM
Compound 3 was reported as a limit (the forecaster's own chance of this, stated with the estimate: 75%); the middle value lies beyond the limit too.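

No new step can be read, since compound 2 and compound 3 each give only a limit of the assay, not a number: the limit of > 20000 nM in this assay, at which 3 of the 3 values shown sit.

The compounds shown leave open whether any change to the shared core, the sulfonate ester or the triazole-bearing side arm gives a measurable number in this assay at all.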